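The source may hold more compounds than are shown below. What is called first, only, known or untested is meant among the compounds shown, and "the series" means these compounds.

For the measured compounds named here, compound 3 `COc1ccc(C(=O)Nc2cccc(-c3ccnc4c(NC(C)=O)cccc34)c2)cc1OC` gives 5300 nM in a functional assay on A375P cells (Homo sapiens) for antiproliferative activity, read by MTT assay, with a stated time of 48 h (a lower number here means a stronger inhibitor, a higher number a weaker inhibitor), the second highest of the three numbers measured so far. Compound 1 `COc1ccc(C(=O)Nc2cccc(-c3ccnc4c(N)cccc34)c2)cc1OC` gives 9500 nM in this assay, and compound 2 `Nc1cccc2c(-c3cccc(NC(=O)c4cc(C(F)(F)F)cc(C(F)(F)F)c4)c3)ccnc12` gives 3400 nM. Compound 1 and compound 3 differ only by an acetyl in place of hydrogen on a nitrogen of the shared core, and that step is a 1.8-fold lower number from compound 1 to compound 3 (0.25 log units; within the scatter). Compound 4 `CC(=O)Nc1cccc2c(-c3cccc(NC(=O)c4cc(Cl)cc(C(F)(F)F)c4)c3)ccnc12` keeps the acetyl of compound 3 and alters the group on the carbonyl carbon: 3-chloro-5-(trifluoromethyl)phenyl in place of 3,4-dimethoxyphenyl on a carbonyl carbon. Going by the values given here, no measured step matches this change exactly. The closest guide is the pair compound 1 and compound 2, which also differ on the carbonyl carbon, with 3,4-dimethoxyphenyl in compound 1 and a phenyl carrying two trifluoromethyl groups in compound 2, and compound 2 gives the lower of the two numbers. On that basis compound 4 is expected to show a modest shift toward a lower number, a step of about a 2.1-fold lower number from compound 3 to compound 4 (0.33 log units; beyond the scatter). The estimate for compound 4 is 2500 nM, within a range from 900 nM to 7000 nM.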

Compound 4, half-maximal inhibitory concentration: 6200 nM
Compound 4: middle estimate off by 2.5-fold (0.39 log units), on the low side; low and high end bracket the measured number.
By their numbers in this assay, from the lowest: compounds 2, 3, 4 and 1 (each within the scatter of the next, the first and the last beyond it).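

With the acetyl kept in place, 3-chloro-5-(trifluoromethyl)phenyl in place of 3,4-dimethoxyphenyl on the carbonyl carbon is a 1.2-fold higher number from compound 3 to compound 4 (0.07 log units; within the scatter) in this assay, so the two compounds cannot be told apart here. For the compounds shown here, this is the first direct reading of a change at this position with the acetyl present, and it shows that an aromatic ring with no hydrogen-bond acceptors can enter for one with two without moving the number beyond the scatter. No measurement on hand offers an explanation for this result.

Every group shown on this carbonyl carbon is a substituted phenyl ring, so it remains open how a cyclohexyl ring, a longer alkyl chain or a phenyl carrying a carboxylic acid would read. Also open, as far as these compounds go, is how 3-chloro-5-(trifluoromethyl)phenyl would read with hydrogen in place of the acetyl.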